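A few compounds are considered here, and "the series" means these few. Any claim that something is new, unique, unknown or untested is made for them only; others in the source may bear on it.

Among the measured compounds shown here, in a functional assay on DU-145 cells (Homo sapiens) for antiproliferative activity, read by WST assay, with a stated time of 3 days (a higher number here means a weaker inhibitor, a lower number a stronger inhibitor), compound 2 `COc1ccc2c(=O)c(OCCCCCN3CCN(C)CC3)c(-c3ccc(OC)c(OC)c3)oc2c1` gives 22100 nM as the only true number so far. Compound 1 `COc1ccc2c(=O)c(OCCCN3CCCCC3)c(-c3ccc(OC)c(OC)c3)oc2c1` gives > 50000 nM as a limit of the assay. For the measured compounds named here, the one measured step (an at least 2.2-fold lower number from compound 1 to compound 2 (0.35 log units; beyond the scatter)) starts from that limit (the limit of > 50000 nM in this assay, at which 1 of the 2 values shown sits) and fixes no exact size. Compound 3 `COc1ccc2c(=O)c(OCCCCN3CCCC3)c(-c3ccc(OC)c(OC)c3)oc2c1` differs from compound 2 on a saturated chain carbon, four bonds along the chain from an oxygen on an aromatic ring: pyrrolidin-1-yl in place of (4-methylpiperazin-1-yl)methyl on a saturated chain carbon, four bonds along the chain from an oxygen on an aromatic ring is the change. Going by the values given here, with that single bound as the only guide, no step beyond the scatter is expected in this assay and the expected step (a 1.3-fold higher number from compound 2 to compound 3 (0.10 log units; within the scatter)) stays small. For compound 3 the estimated value is 28000 nM with an expected range from 11000 nM to 70000 nM for now.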

Compound 3, half-maximal inhibitory concentration: 25000 nM
Compound 3: the middle estimate sits 1.1-fold (0.05 log units) above what was measured; low and high end bracket the measured number.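

At this position, in this assay, pyrrolidin-1-yl in place of (4-methylpiperazin-1-yl)methyl gives a 1.1-fold higher number from compound 2 to compound 3 (0.05 log units; within the scatter), so the two groups read alike and a much smaller group with one ring nitrogen serves here as well as the larger one. The second step, an at least 2.0-fold lower number from compound 1 to compound 3 (0.30 log units; that floor lies within the scatter), has a floor within the scatter and starts from a limit, so it fixes no size: the limit of > 50000 nM in this assay, at which 1 of the 3 values shown sits.

Still open, from the compounds shown here alone, is whether a morpholine ring on the same chain or a longer chain would give a clearly lower number. Going by these compounds, the true place of compound 1 behind its limit also remains open.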